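Methyl additions on a benzimidazole-bearing thiadiazolo-pyrimidine series

The source may hold more compounds than are shown below. What is called first, only, known or untested is meant among the compounds shown, and "the series" means these compounds.

Three measured compounds share a common core. Compound 1 `Cc1nn2c(-c3nc4cc(Cl)ccc4[nH]3)c(-c3ccccc3)nc2s1` carries a chlorine on its fused ring and an unsubstituted phenyl; in a functional assay on A-375 cells (Homo sapiens) for antiproliferative activity, read by MTT assay (on this read-out higher numbers stand for weaker inhibition and lower numbers for stronger inhibition), compound 1 gives 7700 nM. Compound 2 `Cc1ccc2[nH]c(-c3c(-c4ccc(F)cc4)nc4sc(C)nn34)nc2c1` differs from compound 1 in more than one place, so the difference between the two is not broken down here; in this assay compound 2 gives 7700 nM, level with compound 1 at the digits shown. Compound 3 `Cc1ccc(-c2nc3sc(C)nn3c2-c2nc3cc(Cl)ccc3[nH]2)cc1` arises from compound 1 by methyl in place of hydrogen on an aromatic carbon, and in this assay compound 3 gives 5010 nM, which is a 1.5-fold lower number from compound 1 to compound 3 (0.19 log units; within the scatter).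

Compound 4 `Cc1nn2c(-c3nc4cc(C)c(C)cc4[nH]3)c(-c3ccc(F)cc3)nc2s1` is not yet measured. It arises from compound 2 by methyl in place of hydrogen on an aromatic carbon, the same kind of change as from compound 1 to compound 3, but at a different place: on a ring that is part of a fused system of two rings, ortho to a methyl group, meta and para to a fused ring, rather than para to a large group. Resting on a 1.5-fold lower number from compound 1 to compound 3 (0.19 log units; within the scatter), compound 4 is expected to show a 1.3-fold lower number from compound 2 to compound 4 (0.11 log units; within the scatter) in this assay. The estimate for compound 4 is therefore 6000 nM, between 2500 nM and 15000 nM.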

Compound 4, half-maximal inhibitory concentration: 7600 nM
The estimate for compound 4 lay 1.3-fold (0.10 log units) below the measured number, within the range that was stated.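

In this assay, methyl in place of hydrogen on an aromatic carbon gives a 1.0-fold lower number from compound 2 to compound 4 (0.01 log units; within the scatter). Set beside the earlier step, the same change reads alike on the two cores, although it stands at a different place on each: the same change on two cores in this assay, a 1.5-fold lower number (0.19 log units; within the scatter) from compound 1 to compound 3 and a 1.0-fold lower number (0.01 log units; within the scatter) from compound 2 to compound 4, 1.5-fold (0.18 log units) apart, within the scatter of two such steps. This shows that, on these two pairs, the change leaves the number within the scatter wherever it is carried, but it does not show that methyl is without effect across the series, and with a single pair for each core, the effect of the core cannot be separated from that of the place.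

The compounds shown leave open whether an ethyl group, a methoxy group, an amine or a carboxylic acid on the same aromatic carbon would move the number beyond the scatter. They also leave open whether the two steps would still read alike on a cell line other than the one in this assay.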